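From nitro to amino on the shared core

The source may hold more compounds than are shown below. What is called first, only, known or untested is meant among the compounds shown, and "the series" means these compounds.

The three measured compounds share one core and differ on their aromatic ends. Compound 1 `COc1ccc(/C=C/C(=O)c2ccc(OC)c(N)c2)cc1` gives 43000 nM in a functional assay on B16 cells (Mus musculus) for cytotoxicity, read by MTT assay, with a stated time of 3 days; a lower number here means a stronger inhibitor, a higher number a weaker inhibitor. Compound 2 `COc1cccc(/C=C/C(=O)c2ccc(OC)c(N)c2)c1` gives 33000 nM in this assay. These two values lie within the scatter of each other, so no order between them is claimed.

Compound 3 `COc1ccc(/C=C/C(=O)c2ccc(OC)c([N+](=O)[O-])c2)cc1OC` is reported only as a limit of > 100000 nM in this assay. Compound 3 thus stands at the limit of > 100000 nM in this assay, at which 1 of the 3 values shown sits, apart from compounds 1 and 2, which both return a number.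

Compound 4 `COc1ccc(C(=O)/C=C/c2ccc(OC)c(OC)c2)cc1N` has not yet been tested. It differs from compound 3 by amino in place of nitro on an aromatic carbon. Among the compounds with values here, no step between measured compounds covers this exchange, so the size of the step must be judged from the other two compounds. Compound 1 gives 43000 nM and compound 2 gives 33000 nM, both carrying the amino group, and compound 4 is expected to sit close to them. The step is expected to be an at least 2.5-fold lower number from compound 3 to compound 4 (0.39 log units; beyond the scatter), toward a stronger inhibitor. Compound 4 is therefore estimated at 40000 nM in this assay, within a range from 15000 nM to 120000 nM.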

Compound 4, half-maximal inhibitory concentration: 18000 nM
Estimate against measurement, compound 4: 2.2-fold (0.35 log units) above, and the stated range covers the measured number.
By their numbers in this assay, from the lowest: compounds 4, 2 and 1 (each within the scatter of the next, the first and the last beyond it). At a limit, above all of these: compound 3.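

In this assay, the change from nitro to amino on an aromatic carbon, ortho to a methoxy group, now has a measured step of its own, and that step lies beyond the scatter: an at least 5.5-fold lower number from compound 3 to compound 4 (0.74 log units; beyond the scatter). Compound 3 remains a limit and not a number, so this step has a bound and no exact size: the limit of > 100000 nM in this assay, at which 1 of the 4 values shown sits. With amino in place, methoxy in place of hydrogen on an aromatic carbon gives two readings, one modest and beyond the scatter, a 2.4-fold lower number from compound 1 to compound 4 (0.38 log units; beyond the scatter), and the other within it, a 1.8-fold lower number from compound 2 to compound 4 (0.26 log units; within the scatter), so a gain from this exchange is supported against one of the two amino compounds only.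

The compounds shown leave open whether another group on this aromatic carbon, such as a hydroxyl, an acetamide or a dimethylamino group, would read like amino or like nitro. They also leave open whether the step from nitro to amino keeps its size on the methoxy-substituted ends carried by compound 1 and compound 2.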